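Swapping a benzothiazole for a nitro group in a cytotoxicity screen

The source may report more compounds than this note shows. Statements on the series, on what has been measured and on what is new or still open speak of the compounds shown alone.

Compound 1 `CC1(C)OC(=O)C(=CNc2ccccc2-c2nc3ccccc3s2)C(=O)O1` is one of three close relatives tested in an ADME assay on THP-1 cells (Homo sapiens) for cytotoxicity, read by flow cytometry and propidium iodide staining, with a stated time of 72 h; a higher number here means a weaker inhibitor, a lower number a stronger inhibitor. In this assay compound 1 reaches only the limit > 250000 nM, so no exact number is known for it. Compound 2 `CC1(C)OC(=O)C(=CNc2ccc3ncsc3c2)C(=O)O1` likewise gives only the limit > 500000 nM. Compound 3 `CC1(C)OC(=O)C(=CNc2ccc3[nH]c(=O)[nH]c3c2)C(=O)O1` also stops at the limit > 500000 nM. All three therefore sit at or beyond the edge of what this assay can report, with the limit of > 250000 nM in this assay, at which 1 of the 3 values shown sits, for compound 1 and the limit of > 500000 nM in this assay, at which 2 of the 3 values shown sit, for the other two.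

Compound 4 `CC1(C)OC(=O)C(=CNc2ccccc2[N+](=O)[O-])C(=O)O1` carries a single change from compound 1: nitro in place of 1,3-benzothiazol-2-yl on an aromatic carbon. Among the measured compounds shown here, with every measured relative sitting at a limit, no step in this assay can be sized, and the expected shift from compound 1 to compound 4, a step that the limit leaves unreadable from compound 1 to compound 4, is nothing beyond the scatter. Compound 4 is accordingly expected to read near 400000 nM, within a range from 100000 nM to 2000000 nM, most likely as another limit rather than a number.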

Compound 4, half-maximal inhibitory concentration: > 500000 nM
Compound 4: no number, only a limit; the forecaster's own chance of this, stated with the estimate: 85%; middle value at least 1.2-fold (0.09 log units) away from the limit.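

Compound 1 and compound 4 both stop at limits in this assay, so the step between them cannot be read. The compounds shown leave open at what concentration any of them reaches half-maximal inhibition, and whether this swap changes anything.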